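A few compounds are considered here, and "the series" means these few. Any claim that something is new, unique, unknown or untested is made for them only; others in the source may bear on it.

Compound 3 `C/C(=N\NC(N)=S)c1ccc2c(c1)nc(-c1ccoc1)n2C1CCCCC1` sits at the ceiling of an ADME assay on MDBK cells (Bos taurus) for cytotoxicity, read by MTT assay, with a stated time of 96 h; a lower number here means that less compound is tolerated, a higher number that more compound is tolerated. Compound 3 gives > 100000 nM, which is a limit of the assay and not a number. Compound 1 `C/C(=N\NC(N)=O)c1ccc2c(c1)nc(-c1ccccn1)n2C1CCCCC1`, which also bears pyridin-2-yl, gives > 100000 nM, again a limit of the assay. Compound 2 `COc1ccc(-c2nc3cc(/C(C)=N/NC(N)=S)ccc3n2C2CCCCC2)cc1` gives a true number, 32000 nM. Much of this small set therefore stands at that ceiling: the limit of > 100000 nM in this assay, at which 2 of the 3 values shown sit.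

Compound 4 `C/C(=N\NC(N)=S)c1ccc2c(c1)nc(-c1ccccn1)n2C1CCCCC1` changes one group of compound 3, with pyridin-2-yl in place of furan-3-yl on an aromatic carbon of a five-membered aromatic ring with 2 nitrogen (pyridin-2-yl in place of furan-3-yl on an aromatic carbon). Within the data shown here, the only measured step at this place is an at least 3.1-fold higher number from compound 2 to compound 3 (0.49 log units; beyond the scatter). As far as these compounds go, it shows that a swap here can move the read-out, but its true size stays open, since one end of it is a limit.

That step involves a different outgoing group, so it gives only a loose guide. Compound 1 adds some support for good tolerance of pyridin-2-yl. The expected change is small, either none beyond the scatter or a modest fall, written as an at least 1.4-fold lower number from compound 3 to compound 4 (0.15 log units; that floor lies within the scatter). Compound 4 is estimated at 70000 nM, with an expected range from 30000 nM to 100000 nM.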

Compound 4, half-maximal cytotoxic concentration: 41000 nM
Compound 4: middle estimate off by 1.7-fold (0.23 log units), on the high side, within the range that was stated.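

In this assay, pyridin-2-yl is tolerated less well than furan-3-yl on this aromatic carbon between two ring nitrogen atoms, with an at least 2.4-fold lower number from compound 3 to compound 4 (0.38 log units; beyond the scatter), so a swap of one aromatic ring for another at this place can lower the read-out. Against 4-methoxyphenyl the picture differs: a 1.3-fold higher number from compound 2 to compound 4 (0.11 log units; within the scatter) does not separate the two groups, which leaves furan-3-yl as the one that stands apart among these three sulfur-bearing compounds. The group at the other end of the molecule matters too. With pyridin-2-yl held constant, the sulfur-bearing group of compound 4 in place of the oxygen-bearing group of compound 1 gives an at least 2.4-fold lower number from compound 1 to compound 4 (0.38 log units; beyond the scatter), so the good tolerance seen for compound 1 does not carry over to its sulfur counterpart.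

As far as these compounds go, the true sizes of the steps from compound 3 and compound 1 stay open, since both of those compounds stand at a limit and not at a number: the limit of > 100000 nM in this assay, at which 2 of the 4 values shown sit. Also open is how a methyl group or a carboxylic acid would read at this place, and whether the same exchange of sulfur for oxygen would lower the read-out with furan-3-yl.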